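This account rests on a few compounds, and the source may have more. Where it says the series, first, only, none or still open, it means among the compounds named here.

Of the compounds shown here, three built on one shared core have been measured in a physicochemical assay for lipophilicity, in phosphate buffer, measured as octanol-water partition, with a stated time of 24 h; on this read-out higher numbers stand for higher lipophilicity and lower numbers for lower lipophilicity. Compound 1 `Cc1ccc(Oc2ccc(/C=N/Nc3nc4ccccc4s3)cc2)cc1` gives 5.4, compound 2 `C(=N/Nc1nc2ccccc2s1)\c1ccc(Oc2ccccc2)cc1` gives 5.2, and compound 3 `Cc1cc(Oc2ccc(/C=N/Nc3nc4ccccc4s3)cc2)ccc1Cl` gives 5.5. Compound 3 sits at the upper end of these numbers, yet only by steps that stay within the scatter: a number 0.10 log units higher from compound 1 to compound 3 (within the scatter) and a number 0.30 log units higher from compound 2 to compound 3 (within the scatter). Compound 4 `Brc1ccc(Oc2ccc(/C=N/Nc3nc4ccccc4s3)cc2)cc1` differs from compound 3 in a single place: 4-bromophenyl in place of 4-chloro-3-methylphenyl on an oxygen on an aromatic ring. Going by the values given here, two measured steps bear on this change, a number 0.20 log units lower from compound 1 to compound 2 (within the scatter) and a number 0.30 log units higher from compound 2 to compound 3 (within the scatter), both small. Since compound 4 keeps one halogen but gives up the methyl, a modest downward step is expected, a number 0.40 log units lower from compound 3 to compound 4 (beyond the scatter), likely within the scatter. Compound 4 is therefore estimated at 5.1, between 4.7 and 5.5.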

Compound 4, partition coefficient: 5.5
Compound 4: middle estimate off by 0.40 log units, on the low side; the range from low to high includes it.
By their numbers in this assay, from the lowest: compounds 2, 1, 3 and 4 (each within the scatter of the next).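

In this assay, 4-bromophenyl in place of 4-chloro-3-methylphenyl on this oxygen gives no change at the digits printed from compound 3 to compound 4 (within the scatter) and so shows that this swap, which removes the methyl and exchanges chlorine for bromine, leaves the read-out unmoved. Bromo in place of hydrogen gives a number 0.30 log units higher from compound 2 to compound 4 (within the scatter) and bromo in place of methyl gives a number 0.10 log units higher from compound 1 to compound 4 (within the scatter) on the same ring, so all four compounds remain within the scatter of one another. Nothing available explains this result. Still open, from the compounds shown here alone, is whether an amine or a carboxylic acid on this ring would give a step beyond the scatter.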